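Series notes: one chloro removed from compound 2

The compounds below may be only part of what the source reports. "The series", "measured", "known", "first", "only" and "open" are said of these compounds alone.

Measured so far in a functional assay on HCT-116 cells (Homo sapiens) for inhibition, read by sulforhodamine B assay, with a stated time of 48 h; a higher number here means a weaker inhibitor of growth, a lower number a stronger inhibitor of growth:
compound 1 `CN1CCN(CCCOc2cccc3nc(Nc4ccc(Cl)c(C(F)(F)F)c4)ccc23)CC1`: 1500 nM
compound 2 `CN1CCN(CCCOc2cccc3nc(Nc4cc(Cl)cc(Cl)c4)ccc23)CC1`: 1940 nM

Going by the values given here, of the two numbers, compound 2 carries the larger one, but the only step between them, a 1.3-fold higher number from compound 1 to compound 2 (0.11 log units; within the scatter), lies within the scatter, so the two are not separated by these data.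

Compound 3 `CN1CCN(CCCOc2cccc3nc(Nc4cccc(Cl)c4)ccc23)CC1` differs from compound 2 by hydrogen in place of chloro on an aromatic carbon. Among the compounds with values here, no measured step tests this change: the single step from compound 1 to compound 2 exchanges one substituted phenyl for another and does not remove a chloro. It only shows that a change on this ring left this assay essentially unchanged. With nothing in the data pointing to a large effect, the step of a 1.3-fold higher number from compound 2 to compound 3 (0.11 log units; within the scatter) is expected to be small, at most a modest move towards a higher number. Compound 3 is therefore estimated at 2500 nM, with a range of 1200 nM to 5500 nM.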

Compound 3, concentration for 50% growth inhibition: 1550 nM
Compound 3: the middle estimate sits 1.6-fold (0.21 log units) above what was measured; the range from low to high includes it.
By their numbers in this assay, from the lowest: compounds 1, 3 and 2 (each within the scatter of the next).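

In this assay, hydrogen in place of chloro on this aromatic carbon gives a 1.3-fold lower number from compound 2 to compound 3 (0.10 log units; within the scatter), a direct reading of this change that the earlier step could not provide. On the same nitrogen, the 3-chlorophenyl group stands against the 4-chloro-3-(trifluoromethyl)phenyl group with a 1.0-fold higher number from compound 1 to compound 3 (0.01 log units; within the scatter), so the three aryl groups shown are not separated by these data, and neither the second chloro of compound 2 nor the trifluoromethyl group of compound 1 has a measurable effect here. No other data bear on this result.

The compounds shown leave open what a phenyl carrying no chloro at all would give in this assay. They also leave open whether an amine, a methoxy group or a carboxylic acid on this ring would move the number beyond the scatter.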